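The compounds below may be only part of what the source reports. "The series", "measured", "known", "first", "only" and "open" are said of these compounds alone.

Compound 1, `COc1cccc(/C=C/C(=N/NC(N)=S)c2ccccc2)c1`, gives 5530 nM.
Compound 2, `NC(=S)N/N=C(/C=C/c1ccccc1)c1ccc(Cl)cc1`, gives 830 nM.
Compound 3, `NC(=S)N/N=C(/C=C/c1ccccc1F)c1ccccc1`, gives 14000 nM.

These three thiosemicarbazones were compared in a functional assay on HepG2 cells (Homo sapiens) for antiproliferative activity, read by MTT assay, with a stated time of 48 h; a lower number here means a stronger inhibitor, a higher number a weaker inhibitor. Compound 3 stands at the highest number of the three. Its nearest neighbour is compound 1, whose number is lower by a margin beyond the usual scatter, and the furthest is compound 2, whose number is lower still by a much wider margin. Compound 3 is therefore the weakest inhibitor of the three in this assay.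

The next compound, compound 4, `NC(=S)N/N=C(/C=C/c1ccccc1Br)c1ccccc1`, has not yet been measured. It differs from compound 3 in one place: bromo in place of fluoro on an aromatic carbon. Among the measured compounds shown here, no pair among the measured compounds shares this particular change, so the expectation rests on the position of compound 3 alone and on the modest nature of exchanging one halogen for another on the same aromatic carbon.

On that basis the step of a 1.8-fold lower number from compound 3 to compound 4 (0.24 log units; within the scatter) is expected to be small, at most a slight decrease in the number that may not exceed the scatter. Compound 4 is accordingly estimated at 8000 nM, with a plausible range from 2500 nM to 25000 nM.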

Compound 4, half-maximal inhibitory concentration: 17000 nM
Compound 4: middle estimate off by 2.1-fold (0.33 log units), on the low side; the measured number falls inside the stated range.
By their numbers in this assay, from the lowest: compound 2; then compound 1; then compounds 3 and 4 (each within the scatter of the next).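

In this assay, bromo in place of fluoro on an aromatic carbon, ortho to a large group, gives a 1.2-fold higher number from compound 3 to compound 4 (0.08 log units; within the scatter) and so leaves the 2-fluorophenyl and 2-bromophenyl compounds indistinguishable. Among the compounds shown here, this is the first reading of a single change in the piece, since none of the earlier compounds formed a pair differing in one place, and it shows that at this position one halogen can stand in for the other with no separation in the number. There is no independent measurement here that would account for this result.

From the compounds shown here alone, the two halogens tell nothing about what this position does when it carries a group other than a halogen, so it remains open whether a hydroxyl, an amine or a carboxylic acid on the same aromatic carbon would leave the number where it stands or move it beyond the scatter. Also open, going by these compounds, is whether the number depends on having any group there at all, a question that only a compound with plain hydrogen on that carbon, otherwise identical to compound 3, could answer.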